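A few compounds are considered here, and "the series" means these few. Any claim that something is new, unique, unknown or untested is made for them only; others in the source may bear on it.

Measured so far in an ADME assay for permeability, using PAMPA, at pH 7.4; a higher number here means that the compound crosses the layer faster, a lower number that the compound crosses the layer more slowly:
- compound 1 `Cc1ccc(S(=O)(=O)Nc2ccc(-c3cccc(N(C)C)c3)nn2)cc1`: 32.4 10^-6 cm/s
- compound 2 `Cc1ccc(S(=O)(=O)Nc2ccc(-c3ccccc3N(C)C)nn2)cc1`: 35.7 10^-6 cm/s
- compound 3 `Cc1ccc(S(=O)(=O)Nc2ccc(-c3ccccc3N3CCCC3)nn2)cc1`: 43.5 10^-6 cm/s

All three values lie within the scatter of one another. Compound 3, at 43.5 10^-6 cm/s, therefore stands level with compound 2 and compound 1 in this assay, and the numbers separate none of them.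

The next compound is compound 4 `Cc1ccc(S(=O)(=O)Nc2ccc(-c3ccccc3N3CCCCC3)nn2)cc1`, which has piperidin-1-yl in place of pyrrolidin-1-yl on an aromatic carbon of a six-membered aromatic ring of carbon only, ortho to a large group. The difference is piperidin-1-yl in place of pyrrolidin-1-yl on an aromatic carbon.

For the measured compounds named here, no measured step involves piperidin-1-yl. The nearest evidence is the exchange of dimethylamino for pyrrolidin-1-yl at an aromatic carbon, which gave a 1.2-fold higher number from compound 2 to compound 3 (0.09 log units; within the scatter). That single step stayed inside the scatter, so it offers no support for expecting a clear change in either direction. Nothing beyond the scatter is expected for compound 4.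

The estimated change is a 1.0-fold higher number from compound 3 to compound 4 (0.00 log units; within the scatter), a step that would not be told apart from no change. For compound 4 the expected value is 44 10^-6 cm/s, with an estimated range from 26 10^-6 cm/s to 68 10^-6 cm/s.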

Compound 4, apparent permeability: 50.6 10^-6 cm/s
The estimate for compound 4 lay 1.2-fold (0.06 log units) below the measured number; the range from low to high includes it.
By their numbers in this assay, from the lowest: compounds 1, 2, 3 and 4 (each within the scatter of the next).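

In this assay, piperidin-1-yl in place of pyrrolidin-1-yl on an aromatic carbon of a six-membered aromatic ring of carbon only, ortho to a large group, gives a 1.2-fold higher number from compound 3 to compound 4 (0.07 log units; within the scatter), so a six-membered non-aromatic ring at this place reads the same as a five-membered one. Set against the open-chain group at the same place, piperidin-1-yl in place of dimethylamino gives a 1.4-fold higher number from compound 2 to compound 4 (0.15 log units; within the scatter), and even this wider exchange stays inside the scatter, so dimethylamino, pyrrolidin-1-yl and piperidin-1-yl cannot be told apart here in this assay. No separate measurement is available that could account for how closely these numbers agree.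

The compounds shown leave open whether a ring with a second hetero atom, such as morpholine or piperazine, or a group of another kind, such as a carboxylic acid, would carry the number beyond the scatter at this place. They also leave open whether piperidin-1-yl would read the same at the place where compound 1 carries its dimethylamino group.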